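The source may hold more compounds than are shown below. What is called first, only, known or untested is meant among the compounds shown, and "the series" means these compounds.

Measured so far in an in vitro ADME assay on microsomes from liver (Mus musculus) for pharmacokinetics, read by LC-MS, with a stated time of 10 min, tested at 1 uM; a higher number here means faster removal of the compound, a lower number slower removal:
- compound 1 `CC(C)c1ccc(NC(=O)[C@H]2CN(C)C[C@@H]2c2ccc(/C=C/C(=O)Nc3ccccc3N)cc2)cc1` gives 54 mL/min/kg
- compound 2 `CN1C[C@H](C(=O)Nc2ccc(C(F)(F)F)cc2)[C@@H](c2ccc(/C=C/C(=O)Nc3ccccc3N)cc2)C1` gives 23 mL/min/kg
- compound 3 `Cc1cc(NC(=O)[C@H]2CN(C)C[C@@H]2c2ccc(/C=C/C(=O)Nc3ccccc3N)cc2)ccc1F` gives 62 mL/min/kg

Compound 3 stands at the upper end of this small set. Its value and that of compound 1 lie within the scatter of each other, a 1.1-fold higher number from compound 1 to compound 3 (0.06 log units; within the scatter), so no order between them is claimed; against compound 2 the gap is real, a 2.7-fold higher number from compound 2 to compound 3 (0.43 log units; beyond the scatter). For the measured compounds named here, the only change that moved the number beyond the scatter is a 2.3-fold lower number from compound 1 to compound 2 (0.37 log units; beyond the scatter), with trifluoromethyl in place of isopropyl on an aromatic carbon.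

Compound 4 `CN1C[C@H](C(=O)NC2CCCC2)[C@@H](c2ccc(/C=C/C(=O)Nc3ccccc3N)cc2)C1` differs from compound 3 in one place: cyclopentyl in place of 4-fluoro-3-methylphenyl on an amide-type nitrogen. Going by the values given here, none of the measured steps covers this kind of change; all three compounds carry a substituted phenyl on the amide-type nitrogen, and the two steps that replace one such phenyl by another, a 1.1-fold higher number from compound 1 to compound 3 (0.06 log units; within the scatter) and a 2.7-fold higher number from compound 2 to compound 3 (0.43 log units; beyond the scatter), span from within the scatter to modest. With no aliphatic comparator in the set, the direction cannot be read from the data, and the step is expected to stay within or near the scatter, a 1.1-fold lower number from compound 3 to compound 4 (0.05 log units; within the scatter). Compound 4 is therefore estimated at 55 mL/min/kg, with a range of 28 mL/min/kg to 110 mL/min/kg.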

Compound 4, clearance: 61 mL/min/kg
The estimate for compound 4 lay 1.1-fold (0.04 log units) below the measured number; the measured number falls inside the stated range.
By their numbers in this assay, from the lowest: compound 2; then compounds 1, 4 and 3 (each within the scatter of the next).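

In this assay the first non-aromatic group at this amide-type nitrogen leaves the number level with two of the phenyl amides: cyclopentyl in place of 4-fluoro-3-methylphenyl gives no step beyond the scatter (a 1.0-fold lower number from compound 3 to compound 4 (0.01 log units; within the scatter)), and neither does cyclopentyl in place of 4-isopropylphenyl (a 1.1-fold higher number from compound 1 to compound 4 (0.05 log units; within the scatter)), so among these compounds an aromatic ring on this nitrogen is not needed for a number in this range. Cyclopentyl in place of 4-(trifluoromethyl)phenyl gives a modest step beyond the scatter (a 2.7-fold higher number from compound 2 to compound 4 (0.42 log units; beyond the scatter)), which sets compound 2 apart from the other three and shows that the lower number does not belong to the phenyl amides as a whole. No measured finding is available to explain why compound 2 alone stands apart.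

Still open, from the compounds shown here alone, is whether a longer chain on this amide-type nitrogen, or a cyclopentyl ring carrying an amine or a carboxylic acid, would stay with compound 1, compound 3 and compound 4 or move towards compound 2 at 23 mL/min/kg. Also open, going by these compounds, is whether trifluoromethyl on a cyclopentyl ring would bring the same lower number as it does on the phenyl ring of compound 2.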